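Working notes on a small cytotoxicity series

The source may report more compounds than this note shows. Statements on the series, on what has been measured and on what is new or still open speak of the compounds shown alone.

Measured so far:
- compound 1 `CCOC(=O)c1c(-c2c(Cl)c3ccccc3oc2=O)nn(-c2ccc(OC)cc2)c1C(=O)OCC`: in a functional assay on DU-145 cells (Homo sapiens) for cytotoxicity, read by MTT assay, with a stated time of 48 h (a lower number here means a stronger inhibitor, a higher number a weaker inhibitor), compound 1 gives 25000 nM
- compound 2 `CCOC(=O)c1c(-c2c(Cl)c3ccccc3oc2=O)nn(-c2cccc(Cl)c2)c1C(=O)OCC`: compound 2 gives 24000 nM
- compound 3 `CCOC(=O)c1c(-c2cc3ccccc3oc2=O)nn(-c2ccc(OC)cc2)c1C(=O)OCC`: compound 3 gives 39000 nM

All three values lie close together. The change from compound 1 to compound 2 is 3-chlorophenyl in place of 4-methoxyphenyl on an aromatic nitrogen; it made a step of a 1.0-fold lower number from compound 1 to compound 2 (0.02 log units; within the scatter). The two cores differ as follows: compound 3 differs from compound 1 by hydrogen in place of chloro on an aromatic carbon, and that step was a 1.6-fold higher number from compound 1 to compound 3 (0.19 log units; within the scatter). For compound 2 against compound 3 no step is worked out; their two values are simply those given above.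

Compound 4 `CCOC(=O)c1c(-c2cc3ccccc3oc2=O)nn(-c2cccc(Cl)c2)c1C(=O)OCC` has not yet been measured in this assay. It differs from compound 3 by 3-chlorophenyl in place of 4-methoxyphenyl on an aromatic nitrogen, the same change as from compound 1 to compound 2, at the same place; among the four compounds this change occurs twice. The step from compound 3 to compound 4 is expected to be about as small as the earlier one, a 1.0-fold lower number from compound 3 to compound 4 (0.01 log units; within the scatter), because the earlier pair showed a 1.0-fold lower number from compound 1 to compound 2 (0.02 log units; within the scatter). Compound 4 is therefore estimated at 38000 nM, within a range of 20000 nM to 75000 nM.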

Compound 4, half-maximal inhibitory concentration: 35000 nM
The estimate for compound 4 lay 1.1-fold (0.04 log units) above the measured number; measured number inside the range.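

In this assay, 3-chlorophenyl in place of 4-methoxyphenyl on the aromatic nitrogen gives a 1.1-fold lower number from compound 3 to compound 4 (0.05 log units; within the scatter), and this step agrees with the one on the chloro-bearing core: the same change on two cores in this assay, a 1.0-fold lower number (0.02 log units; within the scatter) from compound 1 to compound 2 and a 1.1-fold lower number (0.05 log units; within the scatter) from compound 3 to compound 4, 1.1-fold (0.03 log units) apart, within the scatter of two such steps. Hydrogen in place of chloro on the aromatic carbon gives a 1.5-fold higher number from compound 2 to compound 4 (0.16 log units; within the scatter), and this step also agrees with its earlier counterpart: the same change on two cores in this assay, a 1.6-fold higher number (0.19 log units; within the scatter) from compound 1 to compound 3 and a 1.5-fold higher number (0.16 log units; within the scatter) from compound 2 to compound 4, 1.1-fold (0.03 log units) apart, within the scatter of two such steps. Each change therefore carries from one core to the other in these four compounds, but every step lies within the scatter, so the agreement is only between steps too small to read as effects, and it does not show how a step beyond the scatter would carry over, or how either change would behave on any further core.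

The compounds shown leave open whether an amine on the ring of the nitrogen substituent, or a longer alkyl chain in its place, would give a step beyond the scatter. The same question stands for a carboxylic acid in place of an ethoxycarbonyl group.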